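The source may report more compounds than this note shows. Statements on the series, on what has been measured and on what is new or still open speak of the compounds shown alone.

In an ADME assay (liver) for pharmacokinetics, with Liver microsome (Rattus norvegicus) as the target, using microsomes (on this read-out lower numbers stand for slow clearance and higher numbers for fast clearance), compound 1, `CNc1nc(NCc2ccc(NC(C)=O)cc2)cc(-c2ccccn2)n1`, gives 35.9 mL/min/kg, the only number among the three results shown. Compound 2, `Cc1nc(NCc2ccc(Cl)cc2)cc(-c2ccccn2)n1`, returns only > 52.3 mL/min/kg, which is a limit of the assay rather than a number. Compound 3, `CNc1nc(NC2(c3ccc(Cl)cc3)CCC2)cc(-c2ccccn2)n1`, likewise returns only the limit > 52.3 mL/min/kg. Given (the limit of > 52.3 mL/min/kg in this assay, at which 2 of the 3 values shown sit), compound 1 alone yields a resolved clearance. For the measured compounds named here, no two measured compounds differ in a single place, so no measured step is known. Compound 4, `CNc1nc(NCc2ccc(NS(C)(=O)=O)cc2)cc(-c2ccccn2)n1`, differs from compound 1 in one place: methylsulfonyl in place of acetyl on a nitrogen on an aromatic ring, that is, acetamido becomes methanesulfonamido. The step of a 1.1-fold lower number from compound 1 to compound 4 (0.05 log units; within the scatter) is expected to stay within the usual scatter, with no clear direction. Compound 4 is therefore estimated at 32 mL/min/kg, most likely between 16 mL/min/kg and 52 mL/min/kg.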

Compound 4, clearance: 33.6 mL/min/kg
Compound 4: the middle estimate sits 1.1-fold (0.02 log units) below what was measured; low and high end bracket the measured number.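

For the compounds shown here, with methylsulfonyl in place of acetyl on a nitrogen on an aromatic ring, this assay shows a 1.1-fold lower number from compound 1 to compound 4 (0.03 log units; within the scatter), the first step that can be read. At this place, the two groups cannot be told apart on this read-out. Compound 4 gives a resolved number, as compound 1 does, and so stays off the limit: the limit of > 52.3 mL/min/kg in this assay, at which 2 of the 4 values shown sit.

From the compounds shown here alone, whether a free amine or a longer chain on the carbonyl at this place would read differently stays open. Compound 2 and compound 3 differ from these compounds in more than one place, so they cannot settle it.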